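The compounds below may be only part of what the source reports. "The series", "measured", "known", "first", "only" and "open" are said of these compounds alone.

The study concerns two measured compounds and one that has not yet been tested. Compound 1, with the structure `CCCCCCCC#CC#CC1=CC(=O)NCCC1`, was tested in a functional assay on SK-OV-3 cells (Homo sapiens) for cytotoxicity; on this read-out lower numbers stand for an effect already at smaller amounts and higher numbers for an effect only at larger amounts of compound; in that assay compound 1 gives > 50 ug/mL, which is a limit of the assay rather than a number. Compound 2, with the structure `C=CCCCCCCCC#CC#C/C=C\C(C)=O`, is the only one of the two with a number: in this assay compound 2 gives 45.1 ug/mL. Going by the values given here, compound 2 therefore stands as the sole numeric point in this assay, and the one other value sits at the limit of > 50 ug/mL in this assay, at which 1 of the 2 values shown sits.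

Compound 3, with the structure `CCCCCCCC#CC#C/C=C\C(C)=O`, is the untested member. It differs from compound 2 in one place: hydrogen in place of vinyl on a saturated chain carbon, seven bonds along the chain from a triple-bonded carbon. Among the compounds with values here, no step between two measured compounds exists here against which this change could be weighed, so the expectation rests on compound 2 alone. The change is expected to shift the outcome only a little, if at all, with a step of a 1.1-fold higher number from compound 2 to compound 3 (0.04 log units; within the scatter) from compound 2 that is expected to stay within the usual scatter. Compound 3 is accordingly estimated at 50 ug/mL, between 25 ug/mL and 100 ug/mL.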

Compound 3, concentration for half-maximal effect: 25.9 ug/mL
The estimate for compound 3 lay 1.9-fold (0.29 log units) above the measured number, within the range that was stated.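

In this assay, putting hydrogen in place of vinyl on a saturated chain carbon, seven bonds along the chain from a triple-bonded carbon, gives a 1.7-fold lower number from compound 2 to compound 3 (0.24 log units; within the scatter). Going by these compounds alone, this is the first step that can be read at this position, and it shows that, in this one assay, the exchange of vinyl for hydrogen, which can also be read as pent-4-en-1-yl to propyl, leaves the two compounds within the usual scatter of each other, so the vinyl group makes no difference that this read-out can resolve. The data shown offer no explanation for this outcome.

Within the data shown here, only this single exchange at this place can be read, so it remains open how an amine, a carboxylic acid, a hydroxyl group or a longer chain would read there in this assay. From the compounds shown here alone, compound 1 gives > 50 ug/mL, which is a limit of the assay and not a number, and so it remains open whether the same exchange of vinyl for hydrogen would read the same way on a core like that of compound 1.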